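The source may report more compounds than this note shows. Statements on the series, on what has been measured and on what is new or still open speak of the compounds shown alone.

Of the compounds shown here, three sharing one core have been measured in a functional assay on SGC-7901 cells (Homo sapiens) for antiproliferative activity, read by MTT assay, with a stated time of 72 h (on this read-out lower numbers stand for stronger inhibition and higher numbers for weaker inhibition), and their numbers lie far apart. Compound 1 `COc1ccc(-c2ss/c(=N/O)c2-c2cc(OC)c(OC)c(OC)c2)cc1` stands highest (17400 nM) and compound 3 `COc1ccc(-c2ss/c(=N/O)c2-c2cc(OC)c(OC)c(OC)c2)cc1N` lies lower (4300 nM). Compound 2 `COc1ccc(-c2ss/c(=N/O)c2-c2cc(OC)c(OC)c(OC)c2)cc1O` has the lowest number of the three (200 nM). Hydroxy in place of hydrogen on an aromatic carbon gave an 87-fold lower number from compound 1 to compound 2 (1.94 log units; beyond the scatter) and amino in place of hydrogen on an aromatic carbon gave a 4.0-fold lower number from compound 1 to compound 3 (0.61 log units; beyond the scatter) while amino in place of hydroxy gave a 22-fold higher number from compound 2 to compound 3 (1.33 log units; beyond the scatter) as the remaining comparison.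

Compound 4 `CO/N=c1/ssc(-c2ccc(OC)c(O)c2)c1-c1cc(OC)c(OC)c(OC)c1` differs from compound 2 by methyl in place of hydrogen on an oxygen, hydroxy to methoxy (methyl in place of hydrogen on an oxygen). Among the measured compounds shown here, none of the measured steps touches that oxygen, so they set no size for this change and show only that single changes elsewhere can be large. With compound 2 already so low (200 nM), a moderate rise is expected in this assay rather than a further drop. The expected change is a 3.0-fold higher number from compound 2 to compound 4 (0.48 log units; beyond the scatter) and it remains uncertain. The estimated value for compound 4 is 600 nM (range 80 nM to 4500 nM).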

Compound 4, half-maximal inhibitory concentration: 10000 nM
For compound 4 the middle estimate is 17-fold (1.22 log units) below the measured one; measured number above the stated range.
By their numbers in this assay, from the lowest: compound 2; then compound 3; then compounds 4 and 1 (each within the scatter of the next).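

Of the steps shown, this is the only one on the oxygen whose other neighbour is the double-bonded nitrogen, and it shows that this position is not indifferent to substitution. In this assay, methyl in place of hydrogen there gave a 50-fold higher number from compound 2 to compound 4 (1.70 log units; beyond the scatter), so a single added carbon at this oxygen costs most of what made compound 2 stand out, and the change moves the number upward, unlike the two steps away from hydrogen on the aromatic carbon. No measurement offered here accounts for the size of this step.

On these data alone, whether ethyl, a longer chain or an acetyl group on this oxygen would raise the number further remains open. As far as these compounds go, it is also open whether methyl at this oxygen would cost as much alongside the amino group of compound 3.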